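A few compounds are considered here, and "the series" means these few. Any claim that something is new, unique, unknown or untested is made for them only; others in the source may bear on it.

Measured so far in an ADME assay on MRC5 cells (Homo sapiens) for cytotoxicity; a lower number here means that less compound is tolerated, a higher number that more compound is tolerated:

- compound 1, `Cc1cn([C@@H]2C[C@H](O)[C@@H](CNC(=O)Nc3ccc(Cl)c(C(F)(F)F)c3)O2)c(=O)[nH]c1=O`. In this assay compound 1 gives > 50000 nM, which is a limit of the assay and not a number.
- compound 2, `Cc1cn([C@@H]2C[C@H](O)[C@@H](CNC(=O)Nc3ccccc3COc3ccccc3)O2)c(=O)[nH]c1=O`. Compound 2 gives > 50000 nM, again a limit.
- compound 3, `Cc1cn([C@@H]2C[C@H](O)[C@@H](CNC(=O)Nc3ccc(OC4CCOCC4)cc3)O2)c(=O)[nH]c1=O`. Compound 3 gives > 50000 nM, also a limit.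

So compound 3 stands where every measured compound stands: at the limit of > 50000 nM in this assay, at which 3 of the 3 values shown sit. None of the three gives a number; each only shows that the cells tolerated as much compound as was tested. Within the data shown here, there is no step between measured compounds to learn from, and no compound among the three that can be called more or less tolerated than another.

The new compound is compound 4, `Cc1cn([C@@H]2C[C@H](O)[C@@H](CNC(=O)Nc3ccc(OCc4cccc(Cl)c4)cc3)O2)c(=O)[nH]c1=O`. It differs from compound 3 in one place: 3-chlorobenzyl in place of oxan-4-yl on an oxygen on an aromatic ring.

Since all three measured compounds share the same core and sit at the same limit whatever group hangs on the outer ring, the change to compound 4 is expected to make no step beyond the scatter, and the step from compound 3 to compound 4 is estimated as a number no higher from compound 3 to compound 4 (the limit leaves the size open). Compound 4 is therefore expected to give about 50000 nM, with a range from 20000 nM to 50000 nM, most likely again reported only as a limit.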

Compound 4, half-maximal cytotoxic concentration: > 50000 nM
Compound 4: no number, only a limit; the forecaster's own chance of this, stated with the estimate: 80%; the middle value lies on the limit itself.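

In this assay compound 4 gives > 50000 nM, which is a limit and not a number. Among these compounds, compound 3 also gives only a limit, and no step from compound 3 to compound 4 can be read. The compounds shown leave open how much of each compound these cells would tolerate, and whether any group on the shared core changes that.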